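Cyano for fluoro on the benzyl ring of compound 3

The source may report more compounds than this note shows. Statements on the series, on what has been measured and on what is new or still open speak of the compounds shown alone.

Compound 3 `C[C@@H]1CN(C(=O)OC(C)(C)C)CCN1c1ncc(OCc2ccc(S(C)(=O)=O)cc2F)cn1` stands highest of the three numbers in an in vitro functional assay on HEK293S cells with Glucose-dependent insulinotropic receptor (Homo sapiens) as the target, read by HTRF and cAMP accumulation, with a stated time of 45 min (a lower number here means a smaller maximal response, a higher number a larger maximal response), at 149%. Compound 1 `C[C@@H]1CN(C(=O)OC(C)(C)C)CCN1c1ncc(OCc2ccc(C#N)cc2)cn1` gives 141%, and compound 2 `C[C@@H]1CN(C(=O)OC(C)(C)C)CCN1c1ncc(OCc2ccc(-n3cnnn3)cc2)cn1` gives 89%. The step of a number 8 percentage points higher from compound 1 to compound 3 (within the scatter) lies within the scatter, whereas a number 52 percentage points lower from compound 1 to compound 2 (beyond the scatter) and a number 60 percentage points higher from compound 2 to compound 3 (beyond the scatter) are large. Compound 4 `C[C@@H]1CN(C(=O)OC(C)(C)C)CCN1c1ncc(OCc2ccc(S(C)(=O)=O)cc2C#N)cn1` differs from compound 3 by cyano in place of fluoro on an aromatic carbon, on the carbon ortho to a large group and meta to the methylsulfonyl group. Among the measured compounds shown here, no measured step exchanges fluoro for cyano on that ring; the only replacement made on that ring so far, a number 8 percentage points higher from compound 1 to compound 3 (within the scatter), stayed within the scatter, so no step beyond the scatter is expected, a number 4 percentage points lower from compound 3 to compound 4 (within the scatter). Compound 4 is therefore expected to give about 145%, with a range from 120% to 168%.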

Compound 4, intrinsic activity: the largest response reached, in percent of the reference agonist's: 142%
Estimate against measurement, compound 4: 3 percentage points above; the range from low to high includes it.
By their numbers in this assay, from the lowest: compound 2; then compounds 1, 4 and 3 (each within the scatter of the next).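

Cyano in place of fluoro on the aromatic carbon ortho to a large group is tolerated in this assay, with a number 7 percentage points lower from compound 3 to compound 4 (within the scatter). This is the first exchange shown at this carbon itself, and the hydrogen-bond acceptor that enters with cyano does not separate compound 4 from compound 3 in this read-out. Nothing measured here bears on the reason for this result.

Open, on these data alone, is whether an amine or a carboxylic acid on this carbon would keep the maximal response. Also open, as far as these compounds go, is whether cyano here keeps it with a group other than methylsulfonyl on the ring.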